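Methylsulfanyl for methoxy: notes on compound 3

The compounds below may be only part of what the source reports. "The series", "measured", "known", "first", "only" and "open" are said of these compounds alone.

Measured in a functional assay on HCT-116 cells (Homo sapiens) for antiproliferative activity, read by MTT assay, with a stated time of 72 h; a higher number here means a weaker inhibitor, a lower number a stronger inhibitor:
- compound 1 `CC(C)c1cccc(NC(=O)CCc2cccc3c2B(O)OC3)c1`: 1600 nM
- compound 2 `COc1ccc(-c2cccc(NC(=O)CCc3cccc4c3B(O)OC4)c2)cc1`: 160 nM

Among the measured compounds shown here, compound 2 holds the lower of the two numbers so far. Compound 3 `CSc1ccc(-c2cccc(NC(=O)CCc3cccc4c3B(O)OC4)c2)cc1` carries methylsulfanyl in place of methoxy on an aromatic carbon, para to a large group (methylsulfanyl in place of methoxy on an aromatic carbon). For the measured compounds named here, the only measured step, a 10-fold lower number from compound 1 to compound 2 (1.00 log units; beyond the scatter), brought in the 4-methoxyphenyl in place of isopropyl. It lies beyond the scatter but does not test this exchange, and no direct comparison of the two groups exists. The expected 1.1-fold higher number from compound 2 to compound 3 (0.03 log units; within the scatter) therefore stays within the scatter in this assay. For compound 3 the estimated value is 170 nM, with an expected range of 70 nM to 400 nM.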

Compound 3, half-maximal inhibitory concentration: 180 nM
The estimate for compound 3 lay 1.1-fold (0.02 log units) below the measured number, and the stated range covers the measured number.
By their numbers in this assay, from the lowest: compounds 2 and 3 (each within the scatter of the next); then compound 1.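

In this assay, the exchange of methoxy for methylsulfanyl on an aromatic carbon, para to a large group, gives a 1.1-fold higher number from compound 2 to compound 3 (0.05 log units; within the scatter), so this position tolerates either group within the scatter. With an 8.9-fold lower number from compound 1 to compound 3 (0.95 log units; beyond the scatter), the advantage over isopropyl no longer rests on 4-methoxyphenyl alone, since 4-(methylsulfanyl)phenyl keeps it. Nothing available explains either step.

Still open, on these data alone, is whether an amine or a carboxylic acid at this position would hold the number. As far as these compounds go, the effect of a longer chain on the oxygen or sulfur also remains unknown.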